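A Methyl Added at the Amide, Watched for Stability

The source may hold more compounds than are shown below. What is called first, only, known or untested is meant among the compounds shown, and "the series" means these compounds.

Compound 1 `CCOC(=O)NC/C=C\CN(C)C[C@H]1O[C@@H](n2c(C)nc3c(N)ncnc32)[C@H](O)[C@@H]1O` and compound 2 `Cc1nc2c(N)ncnc2n1[C@@H]1O[C@H](CN(C)C/C=C\CNC(=O)OC(C)C)[C@@H](O)[C@H]1O` differ by one change, (methyl in place of hydrogen on a saturated chain carbon bound to an oxygen next to a carbonyl group and a saturated chain carbon). In an ADME assay on microsomes from liver (Mus musculus) for metabolic stability, read by LC-MS, using NADPH, tested at 1 uM (on this read-out lower numbers stand for a shorter-lived compound and higher numbers for a longer-lived compound), compound 1 reaches only a limit of the assay, > 1.5 h. In this assay compound 2 likewise gives a limit, > 1.5 h. The step that the two limits leave unreadable from compound 1 to compound 2 cannot be read because the limit of > 1.5 h in this assay, at which 2 of the 3 values shown sit, hides both ends. Compound 3 `CC(=O)NC/C=C\CN(C)C[C@H]1O[C@@H](n2cnc3c(N)ncnc32)[C@H](OC(C)=O)[C@@H]1OC(C)=O` has a different core; the difference between the two cores is not broken down here. In this assay, among the measured compounds shown here, compound 3 gives 0.11 h, the only plain number among the three. Compound 4 `CCC(=O)NC/C=C\CN(C)C[C@H]1O[C@@H](n2cnc3c(N)ncnc32)[C@H](OC(C)=O)[C@@H]1OC(C)=O`, still unmeasured, differs from compound 3 by methyl in place of hydrogen on a saturated chain carbon bound to a carbonyl carbon. This is the same kind of change as from compound 1 to compound 2, but the place differs: on a saturated chain carbon bound to an oxygen next to a carbonyl group and a saturated chain carbon before, on a saturated chain carbon bound to a carbonyl carbon now. With the earlier step unreadable, the step of a 1.1-fold higher number from compound 3 to compound 4 (0.04 log units; within the scatter) is expected to stay within the usual scatter. Compound 4 is therefore estimated at 0.12 h, between 0.05 h and 0.3 h.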

Compound 4, half-life: 0.0767 h
Compound 4: middle estimate off by 1.6-fold (0.19 log units), on the high side; low and high end bracket the measured number.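

In this assay, the methyl that turns acetamido into propanoylamino gives a 1.4-fold lower number from compound 3 to compound 4 (0.16 log units; within the scatter), so on the core of compound 3 this change has no readable effect on the half-life. Compound 1 and compound 2 each sit at a limit of the assay and not at a plain number, so the step between them cannot be read: the limit of > 1.5 h in this assay, at which 2 of the 4 values shown sit. With one readable step on one core, these compounds show nothing about whether the change carries from one core to another.

Still open, going by these compounds, is how a longer chain, such as butanoyl, or an amine on that chain would read on the core of compound 3. Also open, on these data alone, is how a methyl step would read on the core of compound 1 for compounds clear of the limit.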